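The source may report more compounds than this note shows. Statements on the series, on what has been measured and on what is new or still open speak of the compounds shown alone.

The measured compounds are these. Compound 1, `Fc1ccc(NC(=S)Nc2nc3ccc(F)cc3s2)cc1`, gives 47700 nM in a functional assay on B16-F10 cells (Mus musculus) for cytotoxicity, read by MTT assay, with a stated time of 48 h; on this read-out higher numbers stand for weaker inhibition and lower numbers for stronger inhibition. Compound 2, `S=C(Nc1ccccc1)Nc1nc2c(Cl)cccc2s1`, reaches only the limit > 50000 nM in this assay. Compound 3, `S=C(Nc1ccccc1)Nc1nc2ccccc2s1`, likewise reaches only the limit > 50000 nM in this assay.

Compound 3 therefore stands at the limit of this assay, with no number of its own; the line the limit of > 50000 nM in this assay, at which 2 of the 3 values shown sit, shows that two of the three values sit there. Going by the values given here, the one measured step, a step that the two limits leave unreadable from compound 2 to compound 3, is unreadable since both ends are limits.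

Compound 4, `Fc1ccc(NC(=S)Nc2nc3ccccc3s2)cc1`, differs from compound 3 by fluoro in place of hydrogen on an aromatic carbon. Among the compounds with values here, no measured step bears on this change. The value of compound 1 lies close to the limit, and compound 1 carries this fluoro together with a second fluoro on the shared core; the values of compound 1 and compound 3 show nothing in this assay beyond the scatter. The step from compound 3 to compound 4 is expected to be a step that the limit leaves unreadable from compound 3 to compound 4, none beyond the scatter. Compound 4 is estimated at 55000 nM, within 30000 nM to 100000 nM, and a limit rather than a number is expected as likely.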

Compound 4, half-maximal inhibitory concentration: > 50000 nM
Compound 4: only a limit was reported; the forecaster's own chance of this, stated with the estimate: 60%; the middle value is on the limit's open side.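

In this assay compound 4 reaches only the limit > 50000 nM, so fluoro in place of hydrogen at this position, para to a large group, gives no number of its own. The change from compound 3 cannot be read, as both ends are limits, while hydrogen in place of the fluoro on the shared core gives an at least 1.0-fold higher number from compound 1 to compound 4 (0.02 log units; that floor lies within the scatter), which neither shows nor excludes a real change. Most of the small set now rests at one edge of the read-out: the limit of > 50000 nM in this assay, at which 3 of the 4 values shown sit.

Going by these compounds, what an amine or a carboxylic acid at this position would do in this assay stays open. Also open, on these data alone, is whether the fluoro on the shared core of compound 1 matters at all, given that no number exists for compound 4.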